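A few compounds are considered here, and "the series" means these few. Any claim that something is new, unique, unknown or untested is made for them only; others in the source may bear on it.

Measured in a functional assay on U-251 cells (Homo sapiens) for inhibition, read by MTT assay, with a stated time of 2 days; on this read-out higher numbers stand for weaker inhibition of growth and lower numbers for stronger inhibition of growth:

- Compound 1 `Nc1ccccc1NC(=O)CCCNCC(=O)Nc1cccc(Cl)c1`: 19500 nM
- Compound 2 `Nc1ccccc1NC(=O)CCCNCC(=O)Nc1ccc(Cl)cc1`: 11400 nM
- Compound 3 `Nc1ccccc1NC(=O)c1ccc(NCC(=O)Nc2ccc([N+](=O)[O-])cc2)cc1`: 8200 nM

Compound 3, at 8200 nM, lies within the usual scatter of compound 2 at 11400 nM, so these two cannot be told apart here. Compound 1 stands at 19500 nM, and compound 3 stands lower, with a gap beyond the scatter.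

The next compound, compound 4 `COc1ccc(NC(=O)CNc2ccc(C(=O)Nc3ccccc3N)cc2)cc1`, keeps the core of compound 3 and alters a single group: methoxy in place of nitro on an aromatic carbon. The change sits para to a large group, so 4-nitrophenyl becomes 4-methoxyphenyl.

For the measured compounds named here, only one measured step offers any guide, and a weak one: a 1.7-fold lower number from compound 1 to compound 2 (0.23 log units; within the scatter). Going by the values given here, it exchanges one chlorophenyl for another on a different core, and no measured pair replaces a nitro group at all. That single small step gives no direction for the present change, so nothing beyond the scatter is expected in this assay. The expected step is a 1.2-fold higher number from compound 3 to compound 4 (0.06 log units; within the scatter), and a move either way would not be surprising. For compound 4 the estimated value is 9500 nM, with an expected range from 4000 nM to 22000 nM.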

Compound 4, concentration for 50% growth inhibition: 25500 nM
Compound 4: the middle estimate sits 2.7-fold (0.43 log units) below what was measured; the measured number lies above the stated range.
By their numbers in this assay, from the lowest: compounds 3, 2, 1 and 4 (each within the scatter of the next, the first and the last beyond it).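

Replacing nitro with methoxy on this aromatic carbon, para to a large group, gives a 3.1-fold higher number from compound 3 to compound 4 (0.49 log units; beyond the scatter) in this assay, so the methoxy compound inhibits growth more weakly than the nitro compound. This shows that the group at this place on the core of compound 3 can shift the read-out beyond the usual scatter, something the chlorophenyl pair, on a different core and with a step within the scatter, could not show. Nothing measured here explains why these two groups give different results.

From the compounds shown here alone, with only nitro and methoxy compared at this place, it remains open whether a 4-aminophenyl, a 4-carboxyphenyl or a plain phenyl ring on the same core would stand closer to compound 3 or to compound 4. Also open, going by these compounds, is whether the same exchange would have a similar effect on the core of compound 1 and compound 2, where a 4-nitrophenyl and a 4-methoxyphenyl would allow that direct comparison.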